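A secondary amide regained: from diethylamide to pentylamide

This account rests on a few compounds, and the source may have more. Where it says the series, first, only, none or still open, it means among the compounds named here.

The measured compounds:
compound 1 `CC(C)(N)CC(=O)N[C@@H]1CCc2ccccc2N(Cc2ccc(-c3ccccc3C(N)=O)cc2)C1=O`, 0.08 uM
compound 2 `CCNC(=O)c1ccccc1-c1ccc(CN2C(=O)[C@H](NC(=O)CC(C)(C)N)CCc3ccccc32)cc1`, 0.09 uM
compound 3 `CCN(CC)C(=O)c1ccccc1-c1ccc(CN2C(=O)[C@H](NC(=O)CC(C)(C)N)CCc3ccccc32)cc1`, 2 uM

In a functional assay (Pituitary gland cell) with Rattus norvegicus as the target (on this read-out lower numbers stand for an effect already at smaller amounts and higher numbers for an effect only at larger amounts of compound), compound 3 gives the highest number of the three: a 25-fold higher number from compound 1 to compound 3 (1.40 log units; beyond the scatter) and a 22-fold higher number from compound 2 to compound 3 (1.35 log units; beyond the scatter) both mark it out, while a 1.1-fold higher number from compound 1 to compound 2 (0.05 log units; within the scatter) shows that compound 1 and compound 2 sit together. Compound 4 `CCCCCNC(=O)c1ccccc1-c1ccc(CN2C(=O)[C@H](NC(=O)CC(C)(C)N)CCc3ccccc32)cc1` is not yet measured. It differs from compound 3 by pentylamino in place of diethylamino on a carbonyl carbon. This change undoes what set compound 3 apart: the step from compound 2 to compound 3, which replaced the amide hydrogen by ethyl, and the step from compound 1 to compound 3 are the ones that bear on it, and both were large. Compound 4, like compound 2, again carries a hydrogen on the amide-type nitrogen, so a return toward the number of compound 2 is expected, with the longer chain leaving some room for a poorer result. Compound 4 is therefore estimated at 0.15 uM, in the range 0.05 uM to 0.6 uM, which means an expected step of a 13-fold lower number from compound 3 to compound 4 (1.12 log units; beyond the scatter).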

Compound 4, concentration for half-maximal effect: > 1 uM
Compound 4: only a limit was reported (the forecaster's own chance of this, stated with the estimate: 2%); middle value at least 6.6-fold (0.82 log units) from the limit.
By their numbers in this assay, from the lowest: compounds 1 and 2 (each within the scatter of the next); then compound 3.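

In this assay the reading for compound 4 is a limit and not a number: the limit of > 1 uM in this assay, at which 1 of the 4 values shown sits. Even so, a hydrogen on the amide-type nitrogen proves not to be enough at this carbonyl carbon: with pentylamino there, the data show an at least 11-fold higher number from compound 2 to compound 4 (1.04 log units; beyond the scatter) and an at least 12-fold higher number from compound 1 to compound 4 (1.09 log units; beyond the scatter). Where the earlier compounds tied a high number only to the loss of the amide hydrogen, the length of the chain on that nitrogen now also goes with a higher number, although the step from diethylamino to pentylamino cannot be read against the limit.

Open, on these data alone, is how a propyl or butyl chain on this nitrogen would read, and so where between ethyl and pentyl the number rises. Also open, as far as these compounds go, is whether an amine or a carboxylic acid at the end of the pentyl chain would bring the number down.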